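This account rests on a few compounds, and the source may have more. Where it says the series, first, only, none or still open, it means among the compounds named here.

Compounds measured so far, in a functional assay on ZR-75-1 cells (Homo sapiens) for cytotoxicity, read by MTT assay, with a stated time of 72 h; a lower number here means that less compound is needed, a higher number that more compound is needed for the effect:

Compound 1, `CCOC(=O)c1c(C)coc1-c1ccc2c(CC)cccc2c1OC`, gives 3.9 ug/mL.
Compound 2, `CCc1cccc2c(OC)c(-c3occ(C)c3C(=O)NC)ccc12`, reaches only a limit of the assay, > 10 ug/mL.
Compound 3, `CCc1cccc2c(OC)c(-c3occ(C)c3C(=O)On3nnc4ccccc43)ccc12`, likewise reaches only a limit of the assay, > 10 ug/mL.

Compound 2 therefore stands without a number of its own: its value is the same limit that also holds compound 3, namely (the limit of > 10 ug/mL in this assay, at which 2 of the 3 values shown sit). Compound 4, `CCOCc1c(C)coc1-c1ccc2c(CC)cccc2c1OC`, has not been measured. It differs from compound 2 in one place, (ethoxymethyl in place of methylcarbamoyl on an aromatic carbon), so the group with a carbonyl and a hydrogen-bond donor is gone, and an ether chain without a donor stands in its place.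

Within the data shown here, two measured steps bear on this. Going from the ethoxy-carbonyl group of compound 1 to the methylcarbamoyl group gave an at least 2.5-fold higher number from compound 1 to compound 2 (0.40 log units; beyond the scatter), and putting a larger ring-bearing group on that carbonyl oxygen gave an at least 2.5-fold higher number from compound 1 to compound 3 (0.40 log units; beyond the scatter). Among the measured compounds shown here, compound 1, the only one with a number, carries no hydrogen-bond donor on that carbon, as compound 4 will not. Compound 4 is thus expected to return toward the number of compound 1 rather than stay at the limit, with an estimated step of an at least 2.0-fold lower number from compound 2 to compound 4 (0.30 log units; that floor lies within the scatter) whose size cannot be read from a limit. The estimate for compound 4 is 5 ug/mL, expected between 2 ug/mL and 15 ug/mL.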

Compound 4, concentration for half-maximal effect: 9.1 ug/mL
For compound 4 the middle estimate is 1.8-fold (0.26 log units) below the measured one, and the stated range covers the measured number.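

Compound 4 carries ethoxymethyl on this aromatic carbon, with no carbonyl there, and in this assay it still gives a number, so a carbonyl at this position is not needed for a measurable effect. The carbonyl-bearing ester still compares favourably, as ethoxymethyl in place of ethoxycarbonyl gives a 2.3-fold higher number from compound 1 to compound 4 (0.37 log units; beyond the scatter). Against methylcarbamoyl, the step can be stated only as a floor, an at least 1.0-fold lower number from compound 2 to compound 4 (0.04 log units; that floor lies within the scatter), and its true size stays unreadable, as the value it starts from is a limit and not a number: the limit of > 10 ug/mL in this assay, at which 2 of the 4 values shown sit.

The compounds shown leave open whether the ether oxygen in ethoxymethyl contributes anything to the effect. A plain propyl chain, a hydroxymethyl group or a carboxylic acid on this carbon would help to separate the role of that oxygen from the role of the chain.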